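The source may hold more compounds than are shown below. What is called first, only, known or untested is meant among the compounds shown, and "the series" means these compounds.

Compound 1 `N/N=C/c1cc2ccccc2[nH]c1=O` shows the shared core bearing a hydrazone with a free amino group. In a functional assay, read by spectrophotometry, with a stated time of 5 min (a higher number here means a weaker inhibitor, a lower number a stronger inhibitor), compound 1 gives 184000 nM, a weak result. Compound 2 `O=c1[nH]c2ccccc2cc1/C=N/Nc1ccc([N+](=O)[O-])cc1` carries a nitrophenyl group on the hydrazone instead; in this assay compound 2 gives "not active" (no number reported), and no number was obtained for it, so its standing cannot be placed on a value and can only be described as showing no measurable inhibition. Compound 3 `O=c1[nH]c2ccccc2cc1/C=N/Nc1ccccc1` differs from compound 2 by hydrogen in place of nitro on an aromatic carbon. Among the compounds with values here, no measured pair in this set shows what such a change does, and with only the weak value of compound 1 and the inactivity of compound 2 to go on, compound 3 is expected to remain very weak in this assay, with a real chance that again no number is reported. On that basis compound 3 is estimated at 200000 nM, within a range of 50000 nM to 1000000 nM.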

Compound 3, half-maximal inhibitory concentration: 306000 nM
For compound 3 the middle estimate is 1.5-fold (0.18 log units) below the measured one; low and high end bracket the measured number.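

Phenyl in place of hydrogen on the amine nitrogen leaves the result in this assay within the scatter, with a 1.7-fold higher number from compound 1 to compound 3 (0.22 log units; within the scatter), so the aromatic ring on that nitrogen does not by itself abolish the measurable inhibition seen for compound 1. On the aromatic carbon para to a large group, the printed values show a number for compound 3 with hydrogen there, whereas compound 2 with nitro there gives "not active" (no number reported), and the size of this step cannot be read. No measurement at hand explains either observation.

The compounds shown leave open whether an amine or a methoxy group on that aromatic carbon would give a number in this assay. They also leave open how a methyl group or a longer chain on the amine nitrogen would compare with phenyl.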